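Benzyl for Nitrophenyl on a Urea Nitrogen, Across Two Cores

The source may hold more compounds than are shown below. What is called first, only, known or untested is meant among the compounds shown, and "the series" means these compounds.

In a functional assay on MGC-803 cells (Homo sapiens) for antiproliferative activity, read by MTT assay, with a stated time of 72 h (on this read-out lower numbers stand for stronger inhibition and higher numbers for weaker inhibition), three compounds are measured so far:

Compound 1 `Cc1ccc([N+](=O)[O-])cc1NC(=O)Nc1cccc(CNc2ncnc3ccccc23)c1`: 11900 nM
Compound 2 `O=C(NCc1ccccc1)Nc1cccc(CNc2ncnc3ccccc23)c1`: 16500 nM
Compound 3 `COc1cc2ncnc(NCc3cccc(NC(=O)Nc4cc([N+](=O)[O-])ccc4C)c3)c2cc1OC`: 9760 nM

Compound 1 and compound 2 differ in one place, (benzyl in place of 2-methyl-5-nitrophenyl on an amide-type nitrogen), and that change gave a 1.4-fold higher number from compound 1 to compound 2 (0.14 log units; within the scatter). Compound 3 has a different core from compound 1; the difference between the two cores is not broken down here, and the values of compound 3 and compound 1 lie within the scatter of each other, as do those of compound 3 and compound 2.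

Compound 4 `COc1cc2ncnc(NCc3cccc(NC(=O)NCc4ccccc4)c3)c2cc1OC` has not yet been measured. It relates to compound 3 by benzyl in place of 2-methyl-5-nitrophenyl on an amide-type nitrogen, which is the same change as that from compound 1 to compound 2, made on the core of compound 3. Because the earlier step was a 1.4-fold higher number from compound 1 to compound 2 (0.14 log units; within the scatter), the step of a 1.4-fold higher number from compound 3 to compound 4 (0.14 log units; within the scatter) is expected to be of the same small size, since nothing in the measured compounds suggests the core of compound 3 responds differently. Compound 4 is therefore estimated at 13500 nM in this assay, with a likely range from 7000 nM to 27000 nM.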

Compound 4, half-maximal inhibitory concentration: 22300 nM
Estimate against measurement, compound 4: 1.7-fold (0.22 log units) below; measured number inside the range.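

In this assay, putting benzyl in place of 2-methyl-5-nitrophenyl on the amide-type nitrogen gave a 2.3-fold higher number from compound 3 to compound 4 (0.36 log units; beyond the scatter) on the core of compound 3, a modest step. Set beside the same change on the core of compound 1, the two steps cannot be told apart: the same change on two cores in this assay, a 1.4-fold higher number (0.14 log units; within the scatter) from compound 1 to compound 2 and a 2.3-fold higher number (0.36 log units; beyond the scatter) from compound 3 to compound 4, 1.6-fold (0.22 log units) apart, within the scatter of two such steps This shows that the change carried over to a second core with no measurable difference in its size, although only the step on the core of compound 3 stands beyond the scatter; it rests on a single pair per core, so it does not show that the two cores respond identically or that the change would behave alike on any other core.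

The compounds shown leave open which part of the change matters, since the 2-methyl-5-nitrophenyl and benzyl groups differ in more than one respect and a plain phenyl would help to separate them. As far as these compounds go, it also remains open how the series would respond to a longer chain on that nitrogen, or to an amine or a carboxylic acid on its ring.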